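Swapping a Methylphenyl Arm for a Dichlorophenyl Arm

The compounds below may be only part of what the source reports. "The series", "measured", "known", "first", "only" and "open" are said of these compounds alone.

Compound 1 `C=CCn1c(=O)/c(=C\c2cccc(C)c2)[nH]c(=O)/c1=C\c1ccccc1OC`: 20400 nM
Compound 2 `C=CCn1c(=O)/c(=C\c2ccc(C)cc2)[nH]c(=O)/c1=C\c1ccccc1OC`: "not active" (no number reported)

Two compounds share a core and differ only in the aryl group on one of the exocyclic double bonds. In a functional assay on BGC-823 cells (Homo sapiens) for cytotoxicity, read by CCK-8 assay, with a stated time of 72 h (a lower number here means a stronger inhibitor, a higher number a weaker inhibitor), compound 1 gives 20400 nM, a weak result. In this assay compound 2 is recorded as "not active" (no number reported), so no single number stands for it and its place relative to compound 1 cannot be set more precisely than "no measurable inhibition where compound 1 showed a weak one".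

Compound 3 `C=CCn1c(=O)/c(=C\c2ccc(Cl)c(Cl)c2)[nH]c(=O)/c1=C\c1ccccc1OC` has not yet been measured in this assay. Its structure differs from compound 2 in one way: 3,4-dichlorophenyl in place of 4-methylphenyl on a double-bonded chain carbon bound to an aromatic carbon. Among the compounds with values here, no measured step between compound 2 and compound 3 exists, so the size of the change can only be guessed from the weak result of compound 1 and the absence of a number for compound 2. A move toward weak but measurable inhibition, roughly in the region of compound 1, seems the most plausible outcome; a second "not active" result is also quite possible.

For compound 3 in this assay the expected value is 25000 nM, with a range of 8000 nM to 80000 nM.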

Compound 3, half-maximal inhibitory concentration: "not active" (no number reported)
No number was reported for compound 3, and the estimate cannot be compared.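

In this assay compound 3 gives "not active" (no number reported), as compound 2 does, so no step can be read between compound 2 and compound 3. The compounds shown leave open how far either lies from compound 1, and whether the two differ from each other at all. No measured evidence bears on this result.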